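Aryl swap at compound 3: working notes toward compound 4

The compounds below may be only part of what the source reports. "The series", "measured", "known", "first", "only" and "open" are said of these compounds alone.

Compound 3 `Clc1ccc(Nc2nnc(-c3ccc(Br)cc3)s2)cc1Cl` gives 7160 nM in an assay on isolated protein for inhibition of beta-glucuronidase (Bos taurus), read by spectrophotometry, with a stated time of 30 min (a lower number here means a stronger inhibitor, a higher number a weaker inhibitor), the second highest of the three numbers. Compound 1 `Clc1ccc(Nc2nnc(-c3ccccc3)s2)cc1Cl` gives 6280 nM, close to it. Compound 2 `COc1ccccc1-c1nnc(Nc2ccc(Cl)c(Cl)c2)s1` gives 22600 nM, well apart from it. Compound 4 `Clc1ccc(Nc2nnc(-c3ccccc3Cl)s2)cc1Cl` carries 2-chlorophenyl in place of 4-bromophenyl on an aromatic carbon. Among the measured compounds shown here, two measured steps bear on this change. The step of a 1.1-fold higher number from compound 1 to compound 3 (0.06 log units; within the scatter) shows that a bromo on the ring leaves the number where it was. The step of a 3.6-fold higher number from compound 1 to compound 2 (0.56 log units; beyond the scatter) shows that a methoxy on the ring costs a modest amount. For the measured compounds named here, a chloro on this ring has no measured precedent, so the expected step is small and leaning toward the weaker side, a 1.3-fold higher number from compound 3 to compound 4 (0.12 log units; within the scatter). Compound 4 is therefore estimated at 9500 nM, with a range from 4000 nM to 25000 nM.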

Compound 4, half-maximal inhibitory concentration: 2160 nM
Compound 4: middle estimate off by 4.4-fold (0.64 log units), on the high side; the whole stated range lies above it.
By their numbers in this assay, from the lowest: compound 4; then compounds 1 and 3 (each within the scatter of the next); then compound 2.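

In this assay a substituent on this aryl ring now lowers the number: chloro in place of hydrogen gives a 2.9-fold lower number from compound 1 to compound 4 (0.46 log units; beyond the scatter). The bromo step from compound 1 to compound 3 stays within the scatter. The change from 4-bromophenyl to 2-chlorophenyl gives a 3.3-fold lower number from compound 3 to compound 4 (0.52 log units; beyond the scatter) and chloro in place of methoxy gives a 10-fold lower number from compound 2 to compound 4 (1.02 log units; beyond the scatter), so the outcome depends on the group and its place on the ring. No measurement shown accounts for these steps.

Whether the gain belongs to chlorine or to its ring position stays open, as 4-chlorophenyl and 2-bromophenyl are absent from the compounds shown. As far as these compounds go, the effect of an amine or a carboxylic acid on this ring also remains open.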